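A few compounds are considered here, and "the series" means these few. Any claim that something is new, unique, unknown or untested is made for them only; others in the source may bear on it.

Measured compounds and values in a physicochemical assay for acid dissociation:
- compound 1 `COc1ccc(Oc2ccc3c(NCCCNCc4cc(F)ccc4OC)ccnc3c2)cc1`: 9.28
- compound 2 `COc1ccc(F)cc1CNCCCNc1ccnc2cc(Cc3cc(C)cc(C)c3)ccc12`: 9.47
- compound 3 `COc1cccc(Oc2ccc3c(NCCCNCc4cc(F)ccc4OC)ccnc3c2)c1`: 9.28

Compound 1 stands level with compound 3 at the digits shown, the two together the lowest of the three numbers; its nearest neighbour is compound 3, no change at the digits printed from compound 1 to compound 3 (within the scatter), and its furthest is compound 2, a number 0.19 log units higher from compound 1 to compound 2 (within the scatter). All three values sit within the scatter of one another, so this assay has so far shown no spread to speak of.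

The step to compound 4 `COc1ccc(Oc2ccc3c(NCCCNCc4cccc(OC)c4O)ccnc3c2)cc1` alters the benzylamine end of the chain: 2-hydroxy-3-methoxyphenyl in place of 5-fluoro-2-methoxyphenyl on a saturated chain carbon bound to an amine nitrogen. Going by the values given here, none of the measured steps touches this part of the molecule; they all exchange the group on the aromatic carbon of the shared core, and each of them, a number 0.19 log units higher from compound 1 to compound 2 (within the scatter), no change at the digits printed from compound 1 to compound 3 (within the scatter), a number 0.19 log units lower from compound 2 to compound 3 (within the scatter), lies within the scatter. Among the compounds with values here, the data therefore give no measured precedent for the change in compound 4, and no direction can be read from them; the expectation is a step of no more than the scatter, a number 0.08 log units lower from compound 1 to compound 4 (within the scatter), with a widened range for want of a comparable step.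

For compound 4 the estimate is 9.2, with a range from 8.6 to 9.7.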

Compound 4, acid dissociation constant: 9.28
For compound 4 the middle estimate is 0.08 log units below the measured one; the range from low to high includes it.
By their numbers in this assay, from the lowest: compounds 1, 3, 4 and 2 (each within the scatter of the next).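

In this assay, going by these compounds alone, 2-hydroxy-3-methoxyphenyl in place of 5-fluoro-2-methoxyphenyl on a saturated chain carbon bound to an amine nitrogen gives no change at the digits printed from compound 1 to compound 4 (within the scatter), so this position now has a measured step of its own, whereas the earlier steps all exchanged the group on an aromatic carbon of the shared core. The exchange removes the fluorine and goes from 0 hydrogen-bond donors to 1 and from 1 hydrogen-bond acceptor to 2, yet the step remains within the scatter. Across compounds 1, 2, 3 and 4, no step shown at either place goes beyond the scatter.

No measurement here indicates which site gives up the proton or what lies behind this flat result. Within the data shown here, still open is whether a carboxylic acid or a second amine on the aryl group at this position, or a longer chain in place of the one in compound 1, would give a step beyond the scatter in this assay.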